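Notes on benzyl and aryl amides of the shared core

The source may report more compounds than this note shows. Statements on the series, on what has been measured and on what is new or still open speak of the compounds shown alone.

Measured so far:
compound 1 `COc1ccc2c(=O)c(/C=C/C(=O)Nc3cccc(Cl)c3)coc2c1` — 1100000 nM
compound 2 `COc1ccc(CNC(=O)/C=C/c2coc3cc(OC)ccc3c2=O)cc1` — 43000 nM
compound 3 `COc1ccc2c(=O)c(/C=C/C(=O)NCc3ccc(C)cc3)coc2c1` — 257000 nM

In an ADME assay on HepG2 2.2.15 cells (Homo sapiens) for cytotoxicity, read by MTT assay, with stated times of 48 h and 9 days (a lower number here means that less compound is tolerated, a higher number that more compound is tolerated), compound 3 gives the second highest of the three numbers. It sits a 4.3-fold lower number from compound 1 to compound 3 (0.63 log units; beyond the scatter) and a 6.0-fold higher number from compound 2 to compound 3 (0.78 log units; beyond the scatter). Both benzyl amides give lower numbers than the aryl amide, as a 26-fold lower number from compound 1 to compound 2 (1.41 log units; beyond the scatter) shows as well.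

Compound 4 `COc1ccc2c(=O)c(/C=C/C(=O)NCc3ccccc3F)coc2c1` is not yet measured. Relative to compound 3 the change is 2-fluorophenyl in place of 4-methylphenyl on a saturated chain carbon bound to an amide-type nitrogen.

The step that bears most directly is a 6.0-fold higher number from compound 2 to compound 3 (0.78 log units; beyond the scatter), a modest change of a substituent on the same ring. Going by the values given here, no measured step involves fluorine, so direction is uncertain; a modest step at most is expected, possibly none beyond the scatter. Compound 4 is therefore estimated at 150000 nM (range 40000 nM to 600000 nM), meaning an expected 1.7-fold lower number from compound 3 to compound 4 (0.23 log units; within the scatter).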

Compound 4, half-maximal cytotoxic concentration: 146000 nM
The estimate for compound 4 lay 1.0-fold (0.01 log units) above the measured number, within the range that was stated.
By their numbers in this assay, from the lowest: compound 2; then compounds 4 and 3 (each within the scatter of the next); then compound 1.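

In this assay the change from 4-methylbenzyl to 2-fluorobenzyl gives a 1.8-fold lower number from compound 3 to compound 4 (0.25 log units; within the scatter) and so does not separate these two benzyl amides. The 4-methoxybenzyl amide stays apart, with a 3.4-fold higher number from compound 2 to compound 4 (0.53 log units; beyond the scatter) on replacing 4-methoxyphenyl with 2-fluorophenyl, while the 3-chlorophenyl amide stays above all three benzyl amides, with a 7.5-fold lower number from compound 1 to compound 4 (0.88 log units; beyond the scatter) as the latest step. No available evidence bears on the origin of these differences.

From the compounds shown here alone, it remains open how this number responds to an amine or a carboxylic acid on the benzyl ring. A longer chain between the amide nitrogen and the ring is equally untested here.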